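A few compounds are considered here, and "the series" means these few. Any claim that something is new, unique, unknown or untested is made for them only; others in the source may bear on it.

Measured compounds in this series:
Compound 1 `CCC(=O)Nc1ccc(S(=O)(=O)N(CC(N)=O)c2ccc(N(CC(N)=O)S(=O)(=O)c3ccc(OC)cc3)c3ccccc23)cc1`. In a functional assay on cells (Peritoneal macrophage, Mus musculus) for cytotoxicity, with a stated time of 24 h (on this read-out lower numbers stand for higher toxicity in this test and higher numbers for lower toxicity in this test), compound 1 gives > 50000 nM, which is a limit of the assay and not a number.
Compound 2 `COc1ccc(S(=O)(=O)N(CC(N)=O)c2ccc(N(CC(N)=O)S(=O)(=O)c3ccc(NC(=O)CN4CCC(C)CC4)cc3)c3ccccc23)cc1`. In this assay compound 2 gives > 50000 nM, again a limit of the assay.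

Compound 1 thus stands only at a limit on the numbers shown; nothing places it more exactly. Among the measured compounds shown here, the one measured step, a step that the two limits leave unreadable from compound 1 to compound 2, cannot be read in size or direction because the limit of > 50000 nM in this assay, at which 2 of the 2 values shown sit: both values sit at that limit.

The step to be followed goes from compound 1 to compound 3 `CCN1CCN(CCCC(=O)Nc2ccc(S(=O)(=O)N(CC(N)=O)c3ccc(N(CC(N)=O)S(=O)(=O)c4ccc(OC)cc4)c4ccccc34)cc2)CC1`. The change is (4-ethylpiperazin-1-yl)methyl in place of hydrogen on a saturated chain carbon, two bonds along the chain from a carbonyl carbon. For the measured compounds named here, no measured step bears directly on this change; the only step available is the unreadable one from compound 1 to compound 2, which leaves no readable size to transfer. On the evidence of compound 1 and compound 2, both at the limit, no step beyond the scatter is expected in this assay, and a limit is the most likely outcome. Compound 3 is therefore estimated at 80000 nM, with a range from 30000 nM to 300000 nM, an expected step that the limit leaves unreadable from compound 1 to compound 3.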

Compound 3, half-maximal cytotoxic concentration: > 100000 nM
Compound 3 was reported as a limit; the forecaster's own chance of this, stated with the estimate: 80%; at least 1.2-fold (0.09 log units) between middle value and limit.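

In this assay compound 3 gives > 100000 nM, a limit of the assay and not a number. Among the compounds shown here, compound 1 and compound 2 also stand at limits, so no step from either of them to compound 3 can be read. The compounds shown leave open the actual half-maximal cytotoxic concentration of each, and whether the side-chain changes alter it at all.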